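The source may hold more compounds than are shown below. What is called first, only, known or untested is meant among the compounds shown, and "the series" means these compounds.

Measured so far in a functional assay on U-87MG ATCC cells for antiproliferative activity against U-87 MG (Homo sapiens), read by MTT assay, with a stated time of 48 h; on this read-out lower numbers stand for stronger inhibition and higher numbers for weaker inhibition:

Compound 1 `C/C(=C\CC/C(C)=C/CC[C@@H]1[C@@]2(C)CCC(=O)C(C)(C)[C@H]2CC[C@@]1(C)O)CC/C=C(\C)C(=O)OCc1cn(-c2ccc(F)cc2)nn1`: > 150000 nM, a limit.
Compound 2 `C#CCOC(=O)/C(C)=C/CC/C(C)=C/CC/C(C)=C/CC[C@@H]1[C@@]2(C)CCC(=O)C(C)(C)[C@H]2CC[C@@]1(C)O`: > 150000 nM, a limit.
Compound 3 `C/C(=C\CC/C(C)=C/CC[C@@H]1[C@@]2(C)CCC(=O)C(C)(C)[C@H]2CC[C@@]1(C)O)CC/C=C(\C)C(=O)OCc1cn(-c2ccc(Br)cc2)nn1`: > 150000 nM, a limit.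

Among the compounds with values here, none of these three compounds has yielded a number, and the series so far shows a single result: the limit of > 150000 nM in this assay, at which 3 of the 3 values shown sit. Compound 3 therefore stands at a limit and not at a measured potency, and it offers no exact starting point for comparison.

The next compound, compound 4 `C/C(=C\CC/C(C)=C/CC[C@@H]1[C@@]2(C)CCC(=O)C(C)(C)[C@H]2CC[C@@]1(C)O)CC/C=C(\C)C(=O)OCc1cn(-c2cccc(Cl)c2)nn1`, keeps the shared core and the triazole-bearing ester of compound 3 and alters only the aryl group: 3-chlorophenyl in place of 4-bromophenyl on an aromatic nitrogen. In words, 3-chlorophenyl takes the place of 4-bromophenyl on an aromatic nitrogen.

The nearest measured change is the halogen exchange on the aryl ring, a step that the two limits leave unreadable from compound 1 to compound 3. The two replacements of the aryl triazole, a step that the two limits leave unreadable from compound 1 to compound 2 and a step that the two limits leave unreadable from compound 2 to compound 3, bear on it less directly. None of these steps has a readable size, so they give no sign of any sensitivity to the aryl group and no direction for a shift. The expected step is a number no higher from compound 3 to compound 4 (the limit leaves the size open), with no change anticipated beyond the usual scatter, and a further limit is the likeliest report. For compound 4 the estimated value is 150000 nM, with an expected range of 70000 nM to 250000 nM.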

Compound 4, half-maximal inhibitory concentration: 91800 nM
The estimate for compound 4 lay 1.6-fold (0.21 log units) above the measured number, within the range that was stated.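

In this assay, compound 4 is the one compound shown that returns a number and not a limit, while the others remain at a single limit: the limit of > 150000 nM in this assay, at which 3 of the 4 values shown sit.

With 3-chlorophenyl on the aromatic nitrogen, the comparison with the 4-bromophenyl compound gives an at least 1.6-fold lower number from compound 3 to compound 4 (0.21 log units; that floor lies within the scatter), and the comparison with the 4-fluorophenyl compound gives an at least 1.6-fold lower number from compound 1 to compound 4 (0.21 log units; that floor lies within the scatter), while the whole 1-(3-chlorophenyl)-1H-1,2,3-triazol-4-yl group in place of ethynyl gives an at least 1.6-fold lower number from compound 2 to compound 4 (0.21 log units; that floor lies within the scatter). Each of these is only a floor that lies within the scatter, and the steps among compound 1, compound 2 and compound 3 cannot be read, so this aryl position now has one measured reading but no firm size of effect.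

Compound 4 differs from compound 3 in both the halogen and its place on the ring, and a 4-chlorophenyl or a 3-bromophenyl group would be needed to tell those two changes apart. Going by these compounds, how an aryl ring carrying an amine or a carboxylic acid would read at this position also stays open.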